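From Trifluoromethyl to Chloro on the Benzyl Ring

This account rests on a few compounds, and the source may have more. Where it says the series, first, only, none or still open, it means among the compounds named here.

Of the compounds shown here, three sharing one core have been measured in a functional assay on B16 cells (Mus musculus) for antiproliferative activity, read by MTT assay, with a stated time of 24 h; a higher number here means a weaker inhibitor, a lower number a stronger inhibitor. Compound 1 `COc1cc(OC)c(-c2coc3cc(OCc4ccc(F)cc4)ccc3c2=O)cc1OC` gives 1120 nM. Compound 2 `COc1cc(OC)c(-c2coc3cc(OCc4ccccc4C)ccc3c2=O)cc1OC` gives 2150 nM, and the step of a 1.9-fold higher number from compound 1 to compound 2 (0.28 log units; within the scatter) stays within the scatter. Compound 3 `COc1cc(OC)c(-c2coc3cc(OCc4ccccc4C(F)(F)F)ccc3c2=O)cc1OC` gives 8550 nM, the highest of the three numbers; the steps of a 7.6-fold higher number from compound 1 to compound 3 (0.88 log units; beyond the scatter) and a 4.0-fold higher number from compound 2 to compound 3 (0.60 log units; beyond the scatter) both lie beyond the scatter, so compound 3 is the weakest inhibitor of the three.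

Compound 4 `COc1cc(OC)c(-c2coc3cc(OCc4ccccc4Cl)ccc3c2=O)cc1OC` differs from compound 3 by chloro in place of trifluoromethyl on an aromatic carbon. The step that bears most directly on this change is a 4.0-fold higher number from compound 2 to compound 3 (0.60 log units; beyond the scatter), where methyl was replaced by trifluoromethyl at the same aromatic carbon and the number rose. Now a group of four heavy atoms leaves and a group of one heavy atom enters at that carbon, so the number is expected to move back down, by an amount similar to that earlier step. For compound 4 the expected value in this assay is 2500 nM, in a range from 1000 nM to 6000 nM, which means an expected step of a 3.4-fold lower number from compound 3 to compound 4 (0.53 log units; beyond the scatter).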

Compound 4, half-maximal inhibitory concentration: 4180 nM
Compound 4: middle estimate off by 1.7-fold (0.22 log units), on the low side; measured number inside the range.
By their numbers in this assay, from the lowest: compounds 1, 2 and 4 (each within the scatter of the next, the first and the last beyond it); then compound 3.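

In this assay, chloro in place of trifluoromethyl gives a 2.0-fold lower number from compound 3 to compound 4 (0.31 log units; beyond the scatter), a modest step that shows the number at this aromatic carbon can come back down when a group of four heavy atoms gives way to one of a single heavy atom. Chloro and methyl cannot be told apart here, with a 1.9-fold higher number from compound 2 to compound 4 (0.29 log units; within the scatter) staying within the scatter, so among these three groups only trifluoromethyl stands apart at this carbon. The 2-chlorobenzyl group still does not match the 4-fluorobenzyl group, as a 3.7-fold higher number from compound 1 to compound 4 (0.57 log units; beyond the scatter) lies beyond the scatter.

Nothing available explains why the number moves with these groups. Still open, from the compounds shown here alone, is how a methoxy group, an amine or a carboxylic acid would read at this same aromatic carbon.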